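Trading a Cyclohexyl Ring for an Ethyl Chain

The compounds below may be only part of what the source reports. "The series", "measured", "known", "first", "only" and "open" are said of these compounds alone.

Of the compounds shown here, three sharing one core have been measured in an assay on cells with melanin-concentrating hormone receptor 1 (Homo sapiens) as the target, read by radioligand binding; on this read-out higher numbers stand for weaker inhibition and lower numbers for stronger inhibition. Compound 1 `CC1CCCC(Oc2cccc3ccc(N)nc23)C1` gives 640 nM, compound 2 `Nc1ccc2cccc(OCCC3CCCCC3)c2n1` gives 808 nM, and compound 3 `Nc1ccc2cccc(OCC3CC4CCC3C4)c2n1` gives 137 nM. Compound 2 holds the highest number of the three; its number and that of compound 1 lie within the usual scatter, so nothing separates them, whereas compound 3 sits clearly lower, a gap beyond the scatter.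

Compound 4 `CCCCOc1cccc2ccc(N)nc12` has not yet been measured. Compared with compound 2 the change is ethyl in place of cyclohexyl on a saturated chain carbon, two bonds along the chain from an oxygen on an aromatic ring. Within the data shown here, no measured pair shows this kind of step, so the expectation rests only on the three numbers above. Since compound 3 carries a larger ring-bearing group on the ether chain and gives 137 nM, removing a ring is expected to move the number upward rather than downward. The step from compound 2 to compound 4 in this assay is therefore estimated as a 2.5-fold higher number from compound 2 to compound 4 (0.39 log units; beyond the scatter). Compound 4 is expected to give about 2000 nM, with a likely range from 700 nM to 6000 nM.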

Compound 4, half-maximal inhibitory concentration: 789 nM
Estimate against measurement, compound 4: 2.5-fold (0.40 log units) above; the range from low to high includes it.
By their numbers in this assay, from the lowest: compound 3; then compounds 1, 4 and 2 (each within the scatter of the next).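

In this assay, ethyl in place of cyclohexyl gives a 1.0-fold lower number from compound 2 to compound 4 (0.01 log units; within the scatter), so this single change leaves the number indistinguishable from where it started. At this place, on a saturated chain carbon two bonds along the chain from an oxygen on an aromatic ring, a group of 2 heavy atoms with no ring therefore reads the same as one of 6 heavy atoms with a six-membered ring, so the cyclohexyl ring is not needed to hold the number at this level. No measurement is available that would explain why the two groups read alike.

Still open, going by these compounds, is whether other groups in this same place, such as a phenyl ring, an amine or a longer chain, would read alike too. This single pair also cannot show whether the same swap would behave the same way on a different core.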